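Swapping methoxy for dimethylamino on compound 2

A few compounds are considered here, and "the series" means these few. Any claim that something is new, unique, unknown or untested is made for them only; others in the source may bear on it.

Compound 1 `Cc1ccccc1-c1nnc(SCCn2c([N+](=O)[O-])cnc2C)o1` gives 32300 nM
Compound 2 `COc1ccc(-c2nnc(SCCn3c([N+](=O)[O-])cnc3C)o2)cc1` gives 10200 nM
Compound 3 `Cc1ncc([N+](=O)[O-])n1CCSc1nnc(-c2ccccc2F)o1` gives 33700 nM

In a functional assay on SGC-7901 cells (Homo sapiens) for cytotoxicity, read by MTT assay, with a stated time of 48 h (on this read-out lower numbers stand for stronger inhibition and higher numbers for weaker inhibition), compound 2 has the lowest number of the three measured compounds. Two modest steps touch it, a 3.2-fold lower number from compound 1 to compound 2 (0.50 log units; beyond the scatter) and then a 3.3-fold higher number from compound 2 to compound 3 (0.52 log units; beyond the scatter) in the other direction, whereas a 1.0-fold higher number from compound 1 to compound 3 (0.02 log units; within the scatter) stays within the scatter. The change from compound 2 to compound 4 `Cc1ncc([N+](=O)[O-])n1CCSc1nnc(-c2ccc(N(C)C)cc2)o1` is dimethylamino in place of methoxy on an aromatic carbon and it puts dimethylamino in place of methoxy on an aromatic carbon, para to a large group. Both modest steps exchange the whole substituted phenyl, so neither isolates this swap. No step beyond the scatter is therefore expected, only an estimated 1.2-fold higher number from compound 2 to compound 4 (0.07 log units; within the scatter) for this exchange. Compound 4 is estimated at 12000 nM with 4000 nM to 35000 nM as the expected range.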

Compound 4, half-maximal inhibitory concentration: 32800 nM
Beside the measured number, compound 4's estimate is 2.7-fold (0.44 log units) below it; low and high end bracket the measured number.
By their numbers in this assay, from the lowest: compound 2; then compounds 1, 4 and 3 (each within the scatter of the next).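

In this assay, within the data shown here, dimethylamino in place of methoxy, para to a large group, gives a 3.2-fold higher number from compound 2 to compound 4 (0.51 log units; beyond the scatter) and so isolates a single group on this aromatic carbon for the first time, since the earlier steps exchanged the whole substituted phenyl. Neither group has a ring or a net charge, yet this one exchange takes the number beyond the scatter. Nothing measured here accounts for the shift. On these data alone, whether hydroxy, ethoxy or a primary amine on this same carbon would stay close to compound 2 remains open.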